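Bromo on the anilino ring of the shared core

The source may hold more compounds than are shown below. What is called first, only, known or untested is meant among the compounds shown, and "the series" means these compounds.

Measured so far in a functional assay on NCI-H1975 cells (Homo sapiens) for inhibition, read by MTT assay, with a stated time of 72 h; on this read-out lower numbers stand for stronger inhibition and higher numbers for weaker inhibition: compound 1 `CCc1cccc(NC(=O)CSc2nc(Nc3ccccc3)c3ccccc3n2)c1` gives 12000 nM; compound 2 `C=CC(=O)Nc1cccc(NC(=O)CSc2nc(Nc3ccccc3)c3ccccc3n2)c1` gives 8120 nM; compound 3 `O=C(CSc1nc(Nc2ccccc2)c2ccccc2n1)Nc1ccc(Br)cc1` gives 10600 nM.

The three numbers sit close together. Compound 2 returns the smallest of them, yet the step of a 1.5-fold lower number from compound 1 to compound 2 (0.17 log units; within the scatter) and the step of a 1.3-fold higher number from compound 2 to compound 3 (0.12 log units; within the scatter) both lie within the scatter, so no ranking is read into this.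

Compound 4 `C=CC(=O)Nc1cccc(NC(=O)CSc2nc(Nc3ccc(Br)cc3)c3ccccc3n2)c1` differs from compound 2 by bromo in place of hydrogen on an aromatic carbon, at the anilino group of the shared core. Among the measured compounds shown here, no measured step touches that position. The steps of a 1.1-fold lower number from compound 1 to compound 3 (0.05 log units; within the scatter) and a 1.3-fold higher number from compound 2 to compound 3 (0.12 log units; within the scatter) introduce 4-bromophenyl, but on the amide-type nitrogen, and neither leaves the scatter. For the measured compounds named here, they are the only indirect guidance and point to no movement.

For compound 4 the expected step is therefore a 1.0-fold lower number from compound 2 to compound 4 (0.01 log units; within the scatter), that is, none beyond the scatter. Compound 4 is estimated at 8000 nM in this assay, within 4000 nM to 16000 nM.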

Compound 4, half-maximal inhibitory concentration: 6280 nM
Compound 4: the middle estimate sits 1.3-fold (0.11 log units) above what was measured, within the range that was stated.
By their numbers in this assay, from the lowest: compounds 4, 2, 3 and 1 (each within the scatter of the next).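

Among the compounds shown here, compound 4 gives the first reading at the anilino group of the shared core: in this assay, the change from anilino to (4-bromophenyl)amino gives a 1.3-fold lower number from compound 2 to compound 4 (0.11 log units; within the scatter) and stays within the scatter. For the compounds shown here, with the (vinylcarbonyl)amino group kept in place, this position therefore takes a bromo, on an aromatic carbon para to a large group, with no step that can be read as a change. Nothing measured on the compounds here speaks to why this step is so small.

From the compounds shown here alone, whether another group at this position, such as an amine, a carboxylic acid or a longer chain, would leave the scatter remains open. Also open, going by these compounds, is whether bromo here would read the same with 3-ethylphenyl or 4-bromophenyl on the amide-type nitrogen.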